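The source may report more compounds than this note shows. Statements on the series, on what has been measured and on what is new or still open speak of the compounds shown alone.

Compound 1 `CC(C)=CCC[C@]1(C)/C=C/[C@@H](OC(=O)C=C(C)C)[C@](C)(O)/C=C/C(=O)/C(CN(C(C)C)C(C)C)=C\C1`: 340 nM
Compound 2 `CC(C)=CCC[C@]1(C)/C=C/[C@@H](OC(=O)C=C(C)C)[C@](C)(O)CCC(=O)/C(CO)=C\C1`: > 40000 nM

Going by the values given here, in a functional assay on SMMC-7721 cells (Homo sapiens) for antiproliferative activity, read by MTT assay, with a stated time of 48 h (on this read-out lower numbers stand for stronger inhibition and higher numbers for weaker inhibition), compound 1 gives 340 nM, the only true number among the two values shown. Compound 2 reaches only (the limit of > 40000 nM in this assay, at which 1 of the 2 values shown sits), which is a limit of this assay and not a number. Compound 3 `CC(C)=CCC[C@]1(C)/C=C/[C@@H](OC(=O)C=C(C)C)[C@](C)(O)/C=C/C(=O)/C(C(=O)N(C(C)C)C(C)C)=C\C1` differs from compound 1 by diisopropylcarbamoyl in place of (diisopropylamino)methyl on a double-bonded ring carbon. Among the compounds with values here, no measured pair mirrors this swap, so the expectation rests on the structural change alone: a step toward weaker inhibition, larger than the usual scatter. Compound 3 is expected to give 3000 nM, within 800 nM to 15000 nM, meaning an estimated step of an 8.8-fold higher number from compound 1 to compound 3 (0.95 log units; beyond the scatter).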

Compound 3, half-maximal inhibitory concentration: 17200 nM
Compound 3: middle estimate off by 5.7-fold (0.76 log units), on the low side; the measured number lies above the stated range.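

In this assay, putting diisopropylcarbamoyl in place of (diisopropylamino)methyl on this double-bonded ring carbon gives a 51-fold higher number from compound 1 to compound 3 (1.70 log units; beyond the scatter), so inhibition depends strongly on which group stands here. The entering group keeps the diisopropyl-bearing nitrogen and adds a carbonyl, so this small edit is enough to weaken inhibition greatly. Nothing measured here explains the size of this step.

Still open, as far as these compounds go, is whether a smaller amine such as dimethylaminomethyl, or a ring amine such as morpholinomethyl, would keep the stronger inhibition seen with compound 1 at this position.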